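This account rests on a few compounds, and the source may have more. Where it says the series, first, only, none or still open, it means among the compounds named here.

Compound 1 `C=CCc1cc(C(C)=O)c(O)cc1OCCCC#N` gives 6% in an assay on isolated protein for binding affinity to leukotriene B4 receptor 1 (Homo sapiens), tested at 1 uM (a higher number here means more inhibition at the concentration tested (going by the name of the read-out), a lower number less inhibition), compound 2 `C=CCc1cc(C(C)=O)c(O)cc1OCCCCCC#N` gives 41%, and compound 3 `C=CCc1cc(C(C)=O)c(O)cc1OCCCCCCCCCCC#N` gives 14%. Compound 3 therefore stands second highest of the three, within the scatter of compound 1 and well below compound 2.

Compound 4 `C=CCCCCOc1cc(O)c(C(C)=O)cc1CC=C` differs from compound 3 in one place: vinyl in place of 6-cyanohexyl on a saturated chain carbon, four bonds along the chain from an oxygen on an aromatic ring. The chain is cut back and its nitrile is gone altogether.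

Going by the values given here, two measured steps bear on chain changes here. Lengthening the chain gave a number 35 percentage points higher from compound 1 to compound 2 (beyond the scatter), and lengthening it much further gave a number 27 percentage points lower from compound 2 to compound 3 (beyond the scatter). Neither step removes the nitrile, so the effect of losing it is not shown by any measured pair. The chain of compound 4 is about the length of that of compound 2, which would argue for a rise, but compound 2 carries the nitrile that compound 4 lacks.

Weighing these, compound 4 is expected to show a number 1 percentage points higher from compound 3 to compound 4 (within the scatter), a change not beyond the scatter. The estimate for compound 4 is 15%, in a range from 3% to 40%.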

Compound 4, a percentage reported as inhibition, at one concentration (the size of the read-out at that concentration, not a potency): 27%
The estimate for compound 4 lay 12 percentage points below the measured number; the range from low to high includes it.
By their numbers in this assay, from the lowest: compounds 1 and 3 (each within the scatter of the next); then compound 4; then compound 2.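

Losing the nitrile does not cost the compounds their inhibition in this assay: vinyl in place of 6-cyanohexyl raises the number (a number 13 percentage points higher from compound 3 to compound 4 (beyond the scatter)), and allyl in place of cyano raises it too (a number 21 percentage points higher from compound 1 to compound 4 (beyond the scatter)). The nitrile can still go with the highest number of the four, since vinyl in place of cyanomethyl lowers it (a number 14 percentage points lower from compound 2 to compound 4 (beyond the scatter)), so what the nitrile is worth here depends on the chain that carries it. No measurement here accounts for these shifts.

The compounds shown leave open whether the chain end needs anything beyond carbon at all, which a plain saturated hexyl chain would test. They also leave open how an amine or a carboxylic acid at the chain end would compare with the nitrile and the vinyl group.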